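The compounds below may be only part of what the source reports. "The series", "measured", "known", "first", "only" and "open" are said of these compounds alone.

Of the compounds shown here, three have been measured so far. In a functional assay on MCF7 cells (Homo sapiens) for inhibition, read by MTT assay, with a stated time of 48 h, tested at 10 uM (a lower number here means less inhibition of growth, a higher number more inhibition of growth at the concentration tested), compound 1 `Cc1cc(=O)c2c(O)c(CN3CCC(c4ccccc4)CC3)c(O)c([C@H]3CCN(C)C[C@H]3O)c2o1` gives 23% and compound 2 `Cc1cc(=O)c2c(O)c(CN(C(C)C)C(C)C)c(O)c([C@H]3CCN(C)C[C@H]3O)c2o1` gives 33%. Compound 3 `CN1CC[C@H](c2c(O)cc(O)c3c(=O)cc(/C=C/c4cccc(Cl)c4)oc23)[C@H](O)C1` gives 82%, the highest of the three numbers, and its gaps to compound 1 and to compound 2 both lie beyond the scatter. Compound 3 is also the only one of the three that carries a 2-(3-chlorophenyl)ethenyl group.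

The next compound, compound 4 `CN1CC[C@H](c2c(O)cc(O)c3c(=O)cc(/C=C/c4cccc(F)c4)oc23)[C@H](O)C1`, keeps that arrangement with one exchange, (fluoro in place of chloro on an aromatic carbon), which places fluoro in place of chloro on an aromatic carbon. The 3-chlorophenyl thus becomes a 3-fluorophenyl, and the rest of the structure stays the same. Among the compounds with values here, no two measured compounds differ in only one place, so the data offer no direct evidence on this exchange. The expectation rests on compound 3 at 82%, the closest measured structure. Inhibition in this assay is expected to remain nearer to that number than to the other two, with no change beyond the scatter. The expected outcome, leaning slightly towards less inhibition, is a number 8 percentage points lower from compound 3 to compound 4 (within the scatter). For compound 4 the estimated value is 74%, with an expected range of 52% to 90%.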

Compound 4, percent growth inhibition at one concentration: 83%
Compound 4: middle estimate off by 9 percentage points, on the low side; the range from low to high includes it.
By their numbers in this assay, from the lowest: compounds 1 and 2 (each within the scatter of the next); then compounds 3 and 4 (each within the scatter of the next).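

In this assay, within the data shown here, the exchange of chloro for fluoro on an aromatic carbon of the six-membered ring gives the first direct reading at this position: a number 1 percentage points higher from compound 3 to compound 4 (within the scatter). The 3-chlorophenyl and the 3-fluorophenyl therefore cannot be told apart in this read-out, and this one exchange leaves the high growth inhibition of the pair in place, with the 2-(3-fluorophenyl)ethenyl group serving as well as the 2-(3-chlorophenyl)ethenyl group at the single concentration tested. Nothing available bears on why the number stays where it is.

The compounds shown leave open whether this position accepts other groups, since one pair with two halogens says nothing about how a methoxy group, a nitrile, a dimethylamine or a plain hydrogen in the same place would read. Among these compounds, they also leave open what the ethenyl link and the aromatic ring it carries contribute, as no measured compound differs from compound 3 or compound 4 in that part alone.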